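This account rests on a few compounds, and the source may have more. Where it says the series, first, only, none or still open, it means among the compounds named here.

Measured compounds:

- Compound 1, `COc1cccnc1Nc1cc2[nH]c(-c3cccc(C(F)(F)F)c3)nc2cn1`: 116000 nM
- Compound 2, `FC(F)(F)c1cccc(-c2nc3cnc(Nc4ncccn4)cc3[nH]2)c1`: 155000 nM
- Compound 3, `FC(F)(F)c1cccc(-c2nc3cnc(Nc4ccncn4)cc3[nH]2)c1`: 200000 nM

All three were tested in a physicochemical assay for solubility, using the shake flask method, measured as kinetic solubility, with a stated time of 20 h, at pH 2 (on this read-out lower numbers stand for lower solubility and higher numbers for higher solubility), and share the same core; they differ only in the six-membered ring that sits on the nitrogen attached to that core. On the numbers shown, compound 3 gives the largest value of the three, but the separations are small: a 1.7-fold higher number from compound 1 to compound 3 (0.24 log units; within the scatter) and a 1.3-fold higher number from compound 2 to compound 3 (0.11 log units; within the scatter) both stay within the scatter, as does a 1.3-fold higher number from compound 1 to compound 2 (0.13 log units; within the scatter).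

Compound 4, `FC(F)(F)c1cccc(-c2nc3cnc(Nc4cccnn4)cc3[nH]2)c1`, has not yet been measured in this assay. It differs from compound 3 in one place: pyridazin-3-yl in place of pyrimidin-4-yl on a nitrogen on an aromatic ring. Within the data shown here, compound 2 to compound 3 is the closest precedent, a swap of one such two-nitrogen ring for another, and it gave a step within the scatter; the other two swaps did the same. A step within the scatter is therefore expected here as well, with no clear direction, a 1.1-fold lower number from compound 3 to compound 4 (0.02 log units; within the scatter). Compound 4 is estimated at 190000 nM, with a range from 90000 nM to 400000 nM.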

Compound 4, solubility: 161000 nM
For compound 4 the middle estimate is 1.2-fold (0.07 log units) above the measured one; the measured number falls inside the stated range.
By their numbers in this assay, from the lowest: compounds 1, 2, 4 and 3 (each within the scatter of the next).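

Pyridazin-3-yl and pyrimidin-4-yl hold the same atoms joined differently, and in this assay this rearrangement alone gives a small step (a 1.2-fold lower number from compound 3 to compound 4 (0.09 log units; within the scatter)). The new ring also stays close to the other two groups (a 1.0-fold higher number from compound 2 to compound 4 (0.02 log units; within the scatter); a 1.4-fold higher number from compound 1 to compound 4 (0.14 log units; within the scatter)), so all four six-membered aromatic rings placed on this nitrogen now sit within the scatter of one another, and the way the atoms are joined in these two rings makes no readable difference here. Nothing measured here explains why these groups read alike.

As far as these compounds go, all four groups are six-membered aromatic rings, so it remains open whether a saturated amine such as morpholine or a carboxylic acid on this nitrogen would separate from them. Changes elsewhere in the molecule, such as replacing the trifluoromethyl group, also remain open.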